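This account rests on a few compounds, and the source may have more. Where it says the series, first, only, none or still open, it means among the compounds named here.

Measured so far in a functional assay on the whole organism for inhibition, with Rattus norvegicus as the target; a lower number here means that less compound is needed, a higher number that more compound is needed for the effect:
compound 1, `CCCCSc1nsnc1C1CN2CCC[C@@H]1C2`: > 3 mg/kg, a limit of the assay rather than a number
compound 2, `CCCCSc1nsnc1C1CN2CCC[C@H]1C2`: 0.007 mg/kg
compound 3, `CCCCSc1nsnc1[C@@H]1CN2CCC[C@H]1C2`: 0.018 mg/kg

Compound 2 holds the lowest of the two numbers given; the nearest is compound 3, reached by a 2.6-fold higher number from compound 2 to compound 3 (0.41 log units; beyond the scatter). Compound 1 gives only a limit in this assay.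

The next step goes to compound 4, `CSc1nsnc1C1CN2CCC[C@H]1C2`, and the change is hydrogen in place of propyl on a saturated chain carbon bound to a sulfur. Among the measured steps, an at least 420-fold lower number from compound 1 to compound 2 (2.63 log units; beyond the scatter) and an at least 160-fold lower number from compound 1 to compound 3 (2.22 log units; beyond the scatter) are large and a 2.6-fold higher number from compound 2 to compound 3 (0.41 log units; beyond the scatter) is modest, but each of them concerns only the drawn configuration at a saturated ring carbon; none touches the butylsulfanyl group, so none bears directly on this change. The expectation rests on compound 2 alone, and the number of compound 4 is expected to stay near it, estimated as a 2.9-fold higher number from compound 2 to compound 4 (0.46 log units; beyond the scatter), with a wide range. Compound 4 is expected at 0.02 mg/kg, between 0.003 mg/kg and 0.15 mg/kg.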

Compound 4, dose for half-maximal effect: 0.14 mg/kg
Estimate against measurement, compound 4: 7.0-fold (0.85 log units) below; low and high end bracket the measured number.
By their numbers in this assay, from the lowest: compound 2; then compound 3; then compound 4. At a limit, above all of these: compound 1.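

Among these compounds, the sulfur-bound chain is the first place where a change other than drawn configuration is seen, and it matters: in this assay, going from butylsulfanyl to methylsulfanyl gives a 20-fold higher number from compound 2 to compound 4 (1.30 log units; beyond the scatter). The step is large, so at this position the butyl chain cannot be treated as interchangeable with a methyl, at least with the configuration drawn in compound 2. Nothing among the data shown explains this step.

The compounds shown leave open how the number runs at other chain lengths, such as ethyl, propyl or hexyl, and whether a branched chain or a butoxy group would behave like butylsulfanyl. Also open, from the compounds shown here alone, is whether the methylsulfanyl step has the same size with the other drawn configurations of the shared core.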